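Efficacy notes: piperidinyl acetamides at the dopamine receptor

The source may hold more compounds than are shown below. What is called first, only, known or untested is meant among the compounds shown, and "the series" means these compounds.

Measured so far:
compound 1 `Cc1cccc(NC(=O)CN2CCC(c3ccccc3C#N)CC2)c1`: 71%
compound 2 `Cc1cc(NC(=O)CN2CCC(c3cccc[n+]3[O-])CC2)ccc1F`: 75%
compound 3 `CSc1cccc(NC(=O)CN2CCC(c3cccc[n+]3[O-])CC2)c1`: 56%

In a functional assay on HEK293 cells for agonist activity at D(4) dopamine receptor (Homo sapiens), read by FLIPR (a higher number here means a larger maximal response, a lower number a smaller maximal response), compound 1 gives 71%. Against the other two numbers it sits second of three: compound 2 gives 75%, a gap to compound 1 that lies within the scatter, so no order between these two can be read; compound 3 gives 56%, lower than compound 1 and beyond the scatter.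

Among the compounds with values here, the one step measured so far is a number 19 percentage points lower from compound 2 to compound 3 (beyond the scatter), a change on the amide-type nitrogen. It says nothing about the group on the saturated ring carbon, which is where compound 4 `Cc1cccc(NC(=O)CN2CCC(c3cccc(C#N)n3)CC2)c1` differs from compound 1: 6-cyanopyridin-2-yl in place of 2-cyanophenyl on a saturated ring carbon. Within the data shown here, compounds 2 and 3 carry a different group at that ring carbon than compound 1 does, but they also differ from compound 1 on the amide-type nitrogen, so no single step connects them.

Among the measured compounds shown here, with no measured step bearing on this change, the expectation for compound 4 in this assay rests on compound 1 alone, and no step beyond the scatter is expected, so a number 3 percentage points lower from compound 1 to compound 4 (within the scatter) is the estimated change. Compound 4 is therefore expected to give about 68%, with a range from 50% to 86%.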

Compound 4, largest response reached (reported as efficacy), in percent of the reference or control that the assay uses: 42%
Compound 4: the middle estimate sits 26 percentage points above what was measured; measured number outside the range, below it.
By their numbers in this assay, from the lowest: compound 4; then compound 3; then compounds 1 and 2 (each within the scatter of the next).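

Changing only the group on the saturated ring carbon, with 6-cyanopyridin-2-yl in place of 2-cyanophenyl, gives in this assay a number 29 percentage points lower from compound 1 to compound 4 (beyond the scatter) and so shows that the maximal response depends on this place and not only on the group at the amide-type nitrogen. The change is small by count, since both groups have the same number of heavy atoms and a nitrile, while the entering group adds a ring nitrogen and a hydrogen-bond acceptor; the two names also number the nitrile differently, so this one step holds two structural differences. Nothing measured here accounts for the step.

Open, on these data alone, is which of these differences carries the step, a question that a plain pyridin-2-yl group or a 3-cyanopyridin-2-yl group at the same ring carbon could help to separate. Also open, as far as these compounds go, is whether the step recurs with the 4-fluoro-3-methylphenyl or 3-(methylsulfanyl)phenyl group on the amide-type nitrogen, and how an amine or a carboxylic acid in place of the nitrile would read.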